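The source may report more compounds than this note shows. Statements on the series, on what has been measured and on what is new or still open speak of the compounds shown alone.

The series rests on a shared core of which two members have been measured. Compound 1 `Cc1cc(O)c(C2=NN(c3ccc(S(N)(=O)=O)cc3)C(c3ccccc3O)C2)cc1Cl` gives, in a functional assay on HOP-62 cells (Homo sapiens) for antiproliferative activity, with a stated time of 48 h (on this read-out lower numbers stand for higher toxicity in this test and higher numbers for lower toxicity in this test), 11700 nM. Compound 2 `Cc1cc(O)c(C2=NN(c3ccc(S(N)(=O)=O)cc3)C(c3ccccc3Cl)C2)cc1Cl` gives in this assay 8530 nM. Within the data shown here, the only measured step, a 1.4-fold lower number from compound 1 to compound 2 (0.14 log units; within the scatter), is a chloro in place of hydroxy on an aromatic carbon; compound 2 therefore stands beside compound 1 on the numbers seen so far, and nothing separates them beyond the scatter.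

Compound 3 `COc1ccc(C2CC(c3cc(Cl)c(C)cc3O)=NN2c2ccc(S(N)(=O)=O)cc2)cc1OC` has not been measured. It differs from compound 2 by 3,4-dimethoxyphenyl in place of 2-chlorophenyl on a saturated ring carbon, which is to say 3,4-dimethoxyphenyl in place of 2-chlorophenyl on a saturated ring carbon. Among the measured compounds shown here, the one step available bears on this only loosely: it too changes the aryl group on that saturated carbon, and it moved the number by a 1.4-fold lower number from compound 1 to compound 2 (0.14 log units; within the scatter), within the scatter. For the measured compounds named here, no step covering a dimethoxyphenyl exists in these data. On that basis compound 3 is expected to land close to compound 2, with a step of a 1.1-fold higher number from compound 2 to compound 3 (0.02 log units; within the scatter) carrying no direction beyond the scatter. The estimate for compound 3 in this assay is 9000 nM, with a range from 4000 nM to 25000 nM.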

Compound 3, concentration lethal to 50% of the cells: 52400 nM
Compound 3: middle estimate off by 5.8-fold (0.77 log units), on the low side, and the stated range ends below it.
By their numbers in this assay, from the lowest: compounds 2 and 1 (each within the scatter of the next); then compound 3.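

The saturated ring carbon bearing the aryl group had seemed indifferent while only the chloro and hydroxy exchange was in view, but in this assay it does respond to a larger change of aryl group. Replacing 2-chlorophenyl with 3,4-dimethoxyphenyl gives a 6.1-fold higher number from compound 2 to compound 3 (0.79 log units; beyond the scatter) and replacing 2-hydroxyphenyl with the same group gives a 4.5-fold higher number from compound 1 to compound 3 (0.65 log units; beyond the scatter) so both modest steps point towards lower toxicity in this test, whichever of the two measured aryl groups is the starting point. The data offered here contain nothing that explains this shift.

The change removes a substituent at the 2-position of the phenyl ring and adds two methoxy groups together, bringing more heavy atoms and two hydrogen-bond acceptors, so the compounds shown cannot separate these contributions or say whether one methoxy group alone would produce the same step. Also open, from the compounds shown here alone, is how an unsubstituted phenyl, a 4-methoxyphenyl, or a phenyl carrying an amine or a carboxylic acid would behave at this carbon, and whether the step would hold with a different group on the rest of the core.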